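This account rests on a few compounds, and the source may have more. Where it says the series, first, only, none or still open, it means among the compounds named here.

Compound 1 `C#CCNCc1cn(-c2cc(NC(=S)NCC)ncn2)cn1` gives 4330 nM in an assay on isolated protein for inhibition of Amine oxidase [flavin-containing] A (Homo sapiens), read by fluorescence and Amplex Red, with a stated time of 15 min; a higher number here means a weaker inhibitor, a lower number a stronger inhibitor.
Compound 2 `C#CCN(CC#N)Cc1cn(-c2cc(NC(=S)NCC)ncn2)cn1` gives > 50000 nM in this assay, which is a limit of the assay and not a number.
Compound 3 `C#CCN(CC#C)Cc1cn(-c2cc(NC(=S)NCC)ncn2)cn1` gives > 50000 nM in this assay, again a limit and not a number.

Within the data shown here, compound 1 therefore stands as the only definite number in this assay; the other two values sit at the limit of > 50000 nM in this assay, at which 2 of the 3 values shown sit. Compound 4 `C#CCN1CCN(Cc2cn(-c3cc(NC(=S)NCC)ncn3)cn2)CC1` has not yet been measured. It differs from compound 1 by 4-propargylpiperazin-1-yl in place of propargylamino on a saturated chain carbon bound to an aromatic carbon. Among the measured compounds shown here, two measured steps bear on this change: an at least 11-fold higher number from compound 1 to compound 2 (1.06 log units; beyond the scatter) and an at least 11-fold higher number from compound 1 to compound 3 (1.06 log units; beyond the scatter). In both, the hydrogen on the amine nitrogen of compound 1 was replaced by a carbon substituent, and each time the number rose beyond the measurable range. Compound 4 likewise carries no hydrogen on an amine nitrogen, so a comparable change is expected. The step that the two limits leave unreadable from compound 2 to compound 3 gives no further guidance. A large rise in this assay is thus expected, a 9.2-fold higher number from compound 1 to compound 4 (0.97 log units; beyond the scatter). Compound 4 is estimated at 40000 nM, within a range from 8000 nM to 200000 nM, and it may well be reported only as a limit.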

Compound 4, half-maximal inhibitory concentration: > 50000 nM
Compound 4 was reported as a limit; the forecaster's own chance of this, stated with the estimate: 55%; middle value at least 1.2-fold (0.09 log units) away from the limit.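

In this assay, replacing propargylamino with 4-propargylpiperazin-1-yl gives an at least 11-fold higher number from compound 1 to compound 4 (1.06 log units; beyond the scatter), so the loss seen with the open-chain groups of compound 2 and compound 3 also appears when the propargyl-bearing nitrogen sits in a six-membered non-aromatic ring. The value of compound 4 is a limit of the assay and not a number. Among the compounds shown, only compound 1 keeps a hydrogen on that amine nitrogen and gives a definite number, and the steps among compound 2, compound 3 and compound 4 cannot be read, leaving them together at one ceiling: the limit of > 50000 nM in this assay, at which 3 of the 4 values shown sit.

As far as these compounds go, whether a methyl group on that amine nitrogen would still give a definite number remains open. So does whether a smaller ring, such as azetidine or pyrrolidine, would do so in place of the piperazine.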